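A few compounds are considered here, and "the series" means these few. Any claim that something is new, unique, unknown or untested is made for them only; others in the source may bear on it.

Measured so far in a functional assay on BXPC-3 cells (Homo sapiens) for antiproliferative activity, read by MTT assay, with a stated time of 24 h; on this read-out higher numbers stand for weaker inhibition and lower numbers for stronger inhibition:
Compound 1 `CCn1c(C(=O)NC2(CO)CC2)ccc1C(CC)(CC)c1ccc(OCS(=O)(=O)c2ccccc2)c(C)c1` gives 45400 nM.
Compound 2 `CCn1c(C(=O)NCCCO)ccc1C(CC)(CC)c1ccc(OCS(=O)(=O)c2ccccc2)c(C)c1` gives 26600 nM.

Compound 2 holds the lowest number of the two; its nearest neighbour is compound 1, and the step of a 1.7-fold lower number from compound 1 to compound 2 (0.23 log units; within the scatter) lies within the scatter, so the two cannot be ordered against each other. Compound 3 `CCn1c(C(=O)N[C@H](CCC(=O)O)C(=O)O)ccc1C(CC)(CC)c1ccc(OCS(=O)(=O)c2ccccc2)c(C)c1` has not yet been measured in this assay. Its change from compound 2 is 1,3-dicarboxypropyl in place of 3-hydroxypropyl on an amide-type nitrogen. Going by the values given here, the only measured step touching the amide-type nitrogen is a 1.7-fold lower number from compound 1 to compound 2 (0.23 log units; within the scatter), an exchange of one hydroxyl-bearing group for another, and that step stayed within the scatter. Among the compounds with values here, no measured step follows the entry of carboxylic acid groups, so the direction of the new step cannot be read from the series and a wide range is needed. Compound 3 is expected at 40000 nM, with a range of 15000 nM to 120000 nM. The step this estimate means, a 1.5-fold higher number from compound 2 to compound 3 (0.18 log units; within the scatter), is expected to be modest, with weaker inhibition somewhat more likely than stronger.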

Compound 3, half-maximal inhibitory concentration: > 50000 nM
Compound 3: no number, only a limit; the forecaster's own chance of this, stated with the estimate: 15%; middle value at least 1.2-fold (0.09 log units) away from the limit.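

In this assay compound 3 carries only a limit, not a number: the limit of > 50000 nM in this assay, at which 1 of the 3 values shown sits. Putting 1,3-dicarboxypropyl on the amide-type nitrogen gives an at least 1.8-fold higher number from compound 2 to compound 3 (0.27 log units; that floor lies within the scatter) and an at least 1.1-fold higher number from compound 1 to compound 3 (0.04 log units; that floor lies within the scatter) and neither floor lies beyond the scatter, so the size of this change stays unfixed. New at this position is that a group with two carboxylic acids reaches the limit of the assay where both hydroxyl-bearing groups gave numbers, and the exchange shows no gain in inhibition.

The compounds shown leave open whether a single carboxylic acid, an amine or a longer hydroxyl-bearing chain on this nitrogen would give a number clearly apart from that of compound 2. They also leave open what the opposite configuration of the defined stereocentre in 1,3-dicarboxypropyl would give.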